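The source may report more compounds than this note shows. Statements on the series, on what has been measured and on what is new or still open speak of the compounds shown alone.

In a functional assay on HL-60 cells (Homo sapiens) for cytotoxicity, read by XTT assay, with a stated time of 3 days (a higher number here means a weaker inhibitor, a lower number a stronger inhibitor), three compounds sharing one core have been measured. For compound 1 `OC[C@H]1O[C@@H](n2cc(F)c3c(-c4ccccc4)ncnc32)[C@H](O)[C@@H]1O`, the assay gives only a limit, > 40000 nM. Compound 2 `OC[C@H]1O[C@@H](n2cc(F)c3c(-c4ccco4)ncnc32)[C@H](O)[C@@H]1O` gives 1200 nM and compound 3 `OC[C@H]1O[C@@H](n2cc(F)c3c(-c4cccs4)ncnc32)[C@H](O)[C@@H]1O` gives 4300 nM, the higher of the two actual numbers. Compound 4 `OC[C@H]1O[C@@H](n2cc(F)c3c(-c4nccs4)ncnc32)[C@H](O)[C@@H]1O` differs from compound 3 by 1,3-thiazol-2-yl in place of thiophen-2-yl on an aromatic carbon. Three measured ring swaps at this place bear on it. Replacing phenyl gave a large step, an at least 33-fold lower number from compound 1 to compound 2 (1.52 log units; beyond the scatter), and an at least modest one, an at least 9.3-fold lower number from compound 1 to compound 3 (0.96 log units; beyond the scatter), but the exchange between the two five-membered rings was only modest, a 3.6-fold higher number from compound 2 to compound 3 (0.55 log units; beyond the scatter). In this assay, a similarly limited step or none beyond the scatter is therefore expected, leaning towards a higher number. The expected step is a 1.5-fold higher number from compound 3 to compound 4 (0.18 log units; within the scatter). Compound 4 is estimated at 6500 nM, within a range of 1800 nM to 30000 nM.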

Compound 4, half-maximal inhibitory concentration: 1000 nM
Compound 4: middle estimate off by 6.5-fold (0.81 log units), on the high side; the measured number lies below the stated range.
By their numbers in this assay, from the lowest: compounds 4 and 2 (each within the scatter of the next); then compound 3. At a limit, above all of these: compound 1.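

In this assay, the 1,3-thiazol-2-yl group shows that exchanging one sulfur-bearing five-membered ring for another still moves the number at this position: a 4.3-fold lower number from compound 3 to compound 4 (0.63 log units; beyond the scatter). Thiophen-2-yl now stands apart from the other two five-membered rings, since furan-2-yl and 1,3-thiazol-2-yl cannot be told apart, with a 1.2-fold lower number from compound 2 to compound 4 (0.08 log units; within the scatter). The step away from phenyl also holds for this third five-membered ring, an at least 40-fold lower number from compound 1 to compound 4 (1.60 log units; beyond the scatter), and compound 1 is a limit: the limit of > 40000 nM in this assay, at which 1 of the 4 values shown sits.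

The compounds shown leave open whether a pyridin-2-yl group would behave like phenyl or like the five-membered rings. They also leave open whether an amine or a methyl group on the 1,3-thiazol-2-yl ring would shift the number further.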